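Chloro for Methoxy: Expected Effect on Vero Cell Viability

The compounds below may be only part of what the source reports. "The series", "measured", "known", "first", "only" and "open" are said of these compounds alone.

Measured so far:
compound 1, `COc1ccc(C2SCC(=O)N2CCN2CCCCC2)cc1`: 89%
compound 2, `O=C1CSC(c2ccc([N+](=O)[O-])cc2)N1CCN1CCCCC1`: 87%
compound 3, `O=C1CSC(c2ccccc2Cl)N1CCN1CCCCC1`: 94%

All three compounds share one core and differ only in the group carried on the aromatic ring. They were tested in an ADME assay on Vero cells (Chlorocebus sabaeus) for cytotoxicity, read by neutral red uptake, tested at 98 ug/mL; on this read-out lower numbers stand for a stronger effect and higher numbers for a weaker effect at the one concentration tested. Compound 1 holds the second highest of the three numbers. Its nearest neighbour is compound 2, whose value 87% lies within the scatter of compound 1, and the furthest is compound 3, whose value 94% is also within the scatter. None of the three is separated from the others by more than the scatter, so no order among them can be read from these numbers.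

The next compound, compound 4, `O=C1CSC(c2ccc(Cl)cc2)N1CCN1CCCCC1`, differs from compound 1 in one way: chloro in place of methoxy on an aromatic carbon. Among the compounds with values here, the one measured step that bears on this is the exchange of the same methoxy group for a nitro group, which gave a number 2 percentage points lower from compound 1 to compound 2 (within the scatter), a change within the scatter. Compound 3, which carries a chloro group on its aromatic ring, gives 94%, again within the scatter of compound 1. Nothing among these numbers points to a step of any size in this assay for compound 4.

Compound 4 is therefore expected to give 90%, between 80% and 98%. The expected step of a number 1 percentage points higher from compound 1 to compound 4 (within the scatter) is estimated to stay within the scatter.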

Compound 4, a percentage reported as activity, at one concentration (the size of the read-out at that concentration, not a potency): 74%
For compound 4 the middle estimate is 16 percentage points above the measured one; measured number below the stated range.
By their numbers in this assay, from the lowest: compound 4; then compounds 2, 1 and 3 (each within the scatter of the next).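

In this assay the aromatic carbon para to a large group is not indifferent to what it carries: chloro in place of methoxy gives a number 15 percentage points lower from compound 1 to compound 4 (beyond the scatter) and chloro in place of nitro gives a number 13 percentage points lower from compound 2 to compound 4 (beyond the scatter) even though methoxy and nitro stayed within the scatter of each other. Having a chlorine on the ring does not by itself set the number either, since 4-chlorophenyl in place of 2-chlorophenyl on the same saturated ring carbon gives a number 20 percentage points lower from compound 3 to compound 4 (beyond the scatter) and so the place of the chlorine counts as well as its presence. No measured property of these groups is available to account for these steps.

Going by these compounds, with only methoxy, nitro and chloro seen at this carbon, it remains open whether the stronger effect at the one concentration tested belongs to chloro alone or would also appear with bromo, methyl or an amine there. On these data alone, it also remains open whether the same steps would hold if the shared core carried a longer chain in place of the one present in all four compounds.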